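This account rests on a few compounds, and the source may have more. Where it says the series, first, only, none or still open, it means among the compounds named here.

Compounds measured so far:
compound 1 `COc1cccc(C(=O)Nc2nnc(/C=C/c3cc(OC)c(OC)c(OC)c3Br)s2)c1`: 170 nM
compound 2 `COc1cc(/C=C/c2nnc(NC(=O)c3ccccc3Br)s2)c(Br)c(OC)c1OC`: 370 nM
compound 3 `COc1cc(/C=C/c2nnc(NC(=O)c3cccc(Cl)c3)s2)c(Br)c(OC)c1OC`: 230 nM

In a functional assay on MCF7 cells (Homo sapiens) for antiproliferative activity, read by MTT assay, with a stated time of 48 h (a higher number here means a weaker inhibitor, a lower number a stronger inhibitor), compound 2 gives the highest of the three numbers; compound 3 is nearest to it and compound 1 is furthest, a 2.2-fold higher number from compound 1 to compound 2 (0.34 log units; beyond the scatter) and a 1.6-fold lower number from compound 2 to compound 3 (0.21 log units; within the scatter) describing those gaps. Compound 4 `COc1cc(/C=C/c2nnc(NC(=O)c3cccc(O)c3)s2)c(Br)c(OC)c1OC` has not yet been measured; it differs from compound 2 by 3-hydroxyphenyl in place of 2-bromophenyl on a carbonyl carbon. Both measured steps at this carbonyl carbon bear on the change: leaving the 2-bromophenyl for a 3-substituted phenyl gave a lower number in compound 3 and compound 1, one step within the scatter, the other beyond it. The 3-hydroxyphenyl of compound 4 is another 3-substituted phenyl, so a modest downward step is expected, a 1.8-fold lower number from compound 2 to compound 4 (0.25 log units; within the scatter). Compound 4 is estimated at 210 nM, between 100 nM and 420 nM.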

Compound 4, half-maximal inhibitory concentration: 360 nM
Compound 4: the middle estimate sits 1.7-fold (0.23 log units) below what was measured; the measured number falls inside the stated range.
By their numbers in this assay, from the lowest: compounds 1, 3, 4 and 2 (each within the scatter of the next, the first and the last beyond it).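

In this assay the 3-hydroxyphenyl does not share the lower number seen with the other 3-substituted phenyls, since a 1.0-fold lower number from compound 2 to compound 4 (0.01 log units; within the scatter) leaves it level with the 2-bromophenyl. Against chloro, hydroxy gives a 1.6-fold higher number from compound 3 to compound 4 (0.19 log units; within the scatter) and so stays level too, whereas hydrogen in place of methyl on the oxygen gives a 2.1-fold higher number from compound 1 to compound 4 (0.33 log units; beyond the scatter) as the only new step beyond the scatter, so at this position methoxy and hydroxy are told apart, though only modestly. No measurement at hand accounts for this difference. Going by these compounds, whether a 3-aminophenyl or a 3-carboxyphenyl on this carbonyl carbon would read like compound 1 or like compound 4 stays open.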